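The source may report more compounds than this note shows. Statements on the series, on what has been measured and on what is new or still open speak of the compounds shown alone.

Two members of the series carry numbers in a functional assay on HCT-116 cells (Homo sapiens) for inhibition, read by sulforhodamine B assay, with a stated time of 72 h (on this read-out higher numbers stand for weaker inhibition and lower numbers for stronger inhibition), so far. Compound 1 `COc1cc(OC)c(C(=O)/C=C/c2cn(-c3ccccc3)nc2-c2ccsc2)c(OC)c1` gives 5200 nM there, while compound 2 `O=C(/C=C/c1cn(-c2ccccc2)nc1-c1cccnc1)c1ccsc1` gives 1300 nM in this assay. Among the measured compounds shown here, compound 2 stands at the lower of the two numbers; the only neighbour, compound 1, sits higher by a step beyond the scatter. Compound 3 `O=C(/C=C/c1cn(-c2ccccc2)nc1-c1cccnc1)c1c[nH]c2ccccc12` is not yet measured; it differs from compound 2 by 1H-indol-3-yl in place of thiophen-3-yl on a carbonyl carbon. For the measured compounds named here, no measured pair shows this change, so the step from compound 2 to compound 3 is expected to be small, likely within the scatter, with the estimate a 1.4-fold lower number from compound 2 to compound 3 (0.16 log units; within the scatter). Compound 3 is estimated at 900 nM in this assay, ranging from 250 nM to 3500 nM.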

Compound 3, half-maximal inhibitory concentration: 6400 nM
Compound 3: middle estimate off by 7.1-fold (0.85 log units), on the low side, and the stated range ends below it.
By their numbers in this assay, from the lowest: compound 2; then compounds 1 and 3 (each within the scatter of the next).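

In this assay, among the compounds shown here, the group on the carbonyl carbon proves sensitive to exchange: 1H-indol-3-yl in place of thiophen-3-yl gives a 4.9-fold higher number from compound 2 to compound 3 (0.69 log units; beyond the scatter) and is the first single-place step. The change adds a six-membered aromatic ring of carbon only and a hydrogen-bond donor, and the higher number comes with both together. Nothing at hand gives a reason for this step.

This pair cannot separate the added ring from the donor. Phenyl or 1-methyl-1H-indol-3-yl on the same carbonyl carbon would bear on that question.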